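This account rests on a few compounds, and the source may have more. Where it says the series, first, only, none or still open, it means among the compounds named here.

Measured so far:
- Compound 1 `O=C(CCc1ccc(C(F)(F)F)cc1)Nc1ccc2nc(N3CCCCC3)ccc2c1`: 110 nM
- Compound 2 `CN(C)c1ccc2cc(NC(=O)CCc3ccc(C(F)(F)F)cc3)ccc2n1`: 110 nM
- Compound 3 `Nc1ccc2cc(NC(=O)CCc3ccc(C(F)(F)F)cc3)ccc2n1`: 720 nM

These three compounds share a core and differ only in the group that sits on the aromatic carbon next to the ring nitrogen. In a functional assay on HEK293 cells for activation of melanin-concentrating hormone receptor 1 (Rattus norvegicus), read by inositol phosphate accumulation (on this read-out higher numbers stand for an effect only at larger amounts of compound and lower numbers for an effect already at smaller amounts), compound 3 gives the highest of the three numbers; it acts only at larger amounts than compound 1 and compound 2, which lie within the scatter of each other.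

Compound 4 `O=C(CCc1ccc(C(F)(F)F)cc1)Nc1ccc2nc(N3CC4CC3CO4)ccc2c1` is the next step from compound 3: a group of 7 heavy atoms (5 carbon, 1 nitrogen, 1 oxygen; 2 five-membered non-aromatic rings with 1 hetero atom each) in place of one nitrogen atom, on an aromatic carbon. The group that enters, with its 2 five-membered non-aromatic rings with 1 hetero atom each, carries no hydrogen-bond donor, like piperidin-1-yl and dimethylamino.

The measured steps that bear on this are a 6.5-fold higher number from compound 1 to compound 3 (0.82 log units; beyond the scatter) and a 6.5-fold higher number from compound 2 to compound 3 (0.82 log units; beyond the scatter). Both run from a group without a hydrogen-bond donor to amino and both raise the number to a similar degree. Going the other way, from amino to a larger group without a donor, a step of about that size toward a lower number is therefore expected for compound 4 in this assay, a 4.8-fold lower number from compound 3 to compound 4 (0.68 log units; beyond the scatter). Compound 4 is estimated at 150 nM, with a range from 60 nM to 400 nM.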

Compound 4, half-maximal effective concentration: 70 nM
Estimate against measurement, compound 4: 2.1-fold (0.33 log units) above; measured number inside the range.
By their numbers in this assay, from the lowest: compounds 4, 1 and 2 (each within the scatter of the next); then compound 3.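

In this assay, the group with 2 five-membered non-aromatic rings gives a 10-fold lower number from compound 3 to compound 4 (1.01 log units; beyond the scatter) and so adds a third group with 0 hydrogen-bond donors that stands well apart from amino, the only group shown that carries one. Compared with the other two groups without a donor, a 1.6-fold lower number from compound 2 to compound 4 (0.20 log units; within the scatter) and a 1.6-fold lower number from compound 1 to compound 4 (0.20 log units; within the scatter) both stay within the scatter, so compound 1, compound 2 and compound 4 cannot be told apart on this read-out. Nothing measured here explains why compound 3 stands apart from these three.

The compounds shown do not tell where methylamino or morpholin-4-yl would fall on this read-out. Nor do they tell whether methoxy or a plain methyl in this place would stay level with compound 1, compound 2 and compound 4.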